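The compounds below may be only part of what the source reports. "The series", "measured", "known", "first", "only" and "open" are said of these compounds alone.

Measured in a functional assay on MCF7 cells (Homo sapiens) for antiproliferative activity, read by sulforhodamine B assay, with a stated time of 48 h; on this read-out lower numbers stand for stronger inhibition and higher numbers for weaker inhibition:
- compound 1 `COc1ccc(/C=C/C(=O)c2ccccc2-c2ccc(F)cc2)cc1`: 670 nM
- compound 2 `COc1cccc(/C=C/C(=O)c2ccccc2-c2ccc(F)cc2)c1OC`: 5300 nM

Compound 1 holds the lower of these two numbers, and its gap to compound 2 lies beyond the usual scatter. The two compounds differ in more than one place, so that gap cannot be assigned to any single change.

Compound 3 `COc1ccc(/C=C/C(=O)c2ccccc2-c2ccc(F)cc2)cc1O` has not yet been measured. It keeps the core of compound 1 and differs from it in one place: hydroxy in place of hydrogen on an aromatic carbon. This is hydroxy in place of hydrogen on an aromatic carbon, ortho to a methoxy group and meta to a large group.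

Among the measured compounds shown here, no measured pair differs in only one place, so no direct precedent sizes this change. For the measured compounds named here, the values of compound 1 at 670 nM and compound 2 at 5300 nM show only that the number can move well beyond the scatter within this small series. A moderate step towards stronger inhibition is expected, though a step within the scatter remains possible. The expected change is a 2.2-fold lower number from compound 1 to compound 3 (0.35 log units; beyond the scatter). In this assay the estimated value for compound 3 is 300 nM, with an expected range from 60 nM to 1500 nM.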

Compound 3, half-maximal inhibitory concentration: 190 nM
Beside the measured number, compound 3's estimate is 1.6-fold (0.20 log units) above it, and the stated range covers the measured number.
By their numbers in this assay, from the lowest: compound 3; then compound 1; then compound 2.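

With a 3.5-fold lower number from compound 1 to compound 3 (0.55 log units; beyond the scatter) in this assay, hydroxy in place of hydrogen gives this series its first comparison that differs in one place only, and the step lies beyond the usual scatter. It shows that this aromatic carbon, ortho to a methoxy group and meta to a large group, is not indifferent to substitution: a group of one heavy atom, with one hydrogen-bond donor and one hydrogen-bond acceptor, is tolerated there and goes with stronger inhibition. Nothing among the data shown bears on why the number falls, so the step stands as a single observation at this one position.

The compounds shown leave open whether an amine, a carboxylic acid or a fluorine atom on this same carbon would move the number as hydroxy does, or whether the response is particular to hydroxy. They also leave open whether hydroxy would give a step of similar size on the core of compound 2, where the methoxy groups are placed differently.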